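Three Limits and a Cinnamyl-Type Change at the Amine

The compounds below may be only part of what the source reports. "The series", "measured", "known", "first", "only" and "open" are said of these compounds alone.

Values in an ADME assay on HL-60 cells (Homo sapiens) for cytotoxicity, read by MTT assay, with a stated time of 24 h (a higher number here means a weaker inhibitor, a lower number a stronger inhibitor), each one a limit:
Compound 1 `CC(C)CN(C)Cc1ccc(C2=CCCN(C)C2)cc1`: > 50000 nM
Compound 2 `CN1CCC=C(c2ccc(CN(C)Cc3ccccc3)cc2)C1`: > 50000 nM
Compound 3 `COc1ccc(CN(C)Cc2ccc(C3=CCCN(C)C3)cc2)cc1`: > 50000 nM

Compound 1 has no exact number in this assay, only a limit of > 50000 nM. Compound 1, compound 2 and compound 3 share one picture: the limit of > 50000 nM in this assay, at which 3 of the 3 values shown sit.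

Compound 4 `CN1CCC=C(c2ccc(CN(C)C/C=C/c3ccccc3)cc2)C1` keeps the core of compound 1 and carries 2-phenylethenyl in place of isopropyl on a saturated chain carbon bound to an amine nitrogen. Two measured compounds change the same place, with phenyl in place of isopropyl and with 4-methoxyphenyl in place of isopropyl. From a step that the two limits leave unreadable from compound 1 to compound 2 and a step that the two limits leave unreadable from compound 1 to compound 3 no size or direction can be carried over, so no step beyond the scatter is expected in this assay. The expected step is a step that the limit leaves unreadable from compound 1 to compound 4. A report of a limit alone is the likeliest outcome for compound 4. For compound 4 the estimated value is 60000 nM, with an expected range from 30000 nM to 120000 nM.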

Compound 4, half-maximal inhibitory concentration: > 50000 nM
Compound 4 ended at the assay's limit (the forecaster's own chance of this, stated with the estimate: 75%); the middle value is on the limit's open side.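

In this assay compound 4 gives > 50000 nM as a limit and not a number. For the compounds shown here, no step among compound 1, compound 2, compound 3 and compound 4 can be read, and all four share one picture: the limit of > 50000 nM in this assay, at which 4 of the 4 values shown sit. The compounds shown leave open how far past the limit each one lies, and so whether they differ at all.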